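This account rests on a few compounds, and the source may have more. Where it says the series, first, only, none or still open, it means among the compounds named here.

Measured so far in a functional assay on A498 cells (Homo sapiens) for antiproliferative activity, with a stated time of 48 h; on this read-out lower numbers stand for higher toxicity in this test and higher numbers for lower toxicity in this test:
- compound 1 `Cc1cc(O)c(C2=NN(c3ccc(S(N)(=O)=O)cc3)C(c3ccccc3Cl)C2)cc1Cl`: in this assay compound 1 gives 61400 nM.
- compound 2 `Cc1cc(O)c(C2=NN(c3ccc(S(N)(=O)=O)cc3)C(/C=C/c3ccccc3)C2)cc1Cl`: in this assay compound 2 gives > 100000 nM, which is a limit of the assay and not a number.
- compound 3 `COc1ccc(C2CC(c3cc(Cl)c(C)cc3O)=NN2c2ccc(S(N)(=O)=O)cc2)cc1OC`: in this assay compound 3 gives > 100000 nM, also a limit of the assay and not a number.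

For the measured compounds named here, compound 1 is the only compound with a number; the other two sit at the limit of > 100000 nM in this assay, at which 2 of the 3 values shown sit. The two measured steps from it are an at least 1.6-fold higher number from compound 1 to compound 2 (0.21 log units; that floor lies within the scatter) and an at least 1.6-fold higher number from compound 1 to compound 3 (0.21 log units; that floor lies within the scatter); both floors lie within the scatter, so neither says more than that the aryl variants reach the limit. The step between compound 2 and compound 3 is unreadable from two limits.

Compound 4 `COc1ccc(C2CC(c3cc(Cl)c(C)cc3O)=NN2c2ccc(S(N)(=O)=O)cc2)c(OC)c1OC` is not yet measured. It differs from compound 1 by 2,3,4-trimethoxyphenyl in place of 2-chlorophenyl on a saturated ring carbon. The closest measured precedent is the step to compound 3, which carries 3,4-dimethoxyphenyl and reports only the limit. The step from compound 1 to compound 4 in this assay is therefore expected to be a 2.4-fold higher number from compound 1 to compound 4 (0.39 log units; beyond the scatter), most likely ending at the limit again. Compound 4 is estimated at 150000 nM, with a range from 60000 nM to 400000 nM.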

Compound 4, concentration lethal to 50% of the cells: 57800 nM
Compound 4: middle estimate off by 2.6-fold (0.41 log units), on the high side; the measured number lies below the stated range.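

In this assay, the saturated ring carbon now carries two quite different aryl groups with numbers that cannot be told apart, since 2,3,4-trimethoxyphenyl in place of 2-chlorophenyl gives a 1.1-fold lower number from compound 1 to compound 4 (0.03 log units; within the scatter). A second number at this position shows that a methoxylated phenyl need not sit at the limit, yet the one-place step from 3,4-dimethoxyphenyl gives only a floor within the scatter (an at least 1.7-fold lower number from compound 3 to compound 4 (0.23 log units; that floor lies within the scatter)), as does the step from 2-phenylethenyl (an at least 1.7-fold lower number from compound 2 to compound 4 (0.23 log units; that floor lies within the scatter)). These two steps stay floors because the values of compound 2 and compound 3 are limits and not numbers: the limit of > 100000 nM in this assay, at which 2 of the 4 values shown sit.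

From the compounds shown here alone, how far either limit compound lies from compound 4 remains open. Also open, going by these compounds, is how this position responds to an aminomethyl group or a carboxylic acid in place of the aryl group.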